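A Second Chloro on the Aryl Ring: Expected Inhibition

A few compounds are considered here, and "the series" means these few. Any claim that something is new, unique, unknown or untested is made for them only; others in the source may bear on it.

Measured compounds:
Compound 1 `CC1=CC[C@@H]2[C@@H](O[C@H](c3ccc(Cl)cc3)OC2(C)C)[C@@H]1O` gives 88% in a functional assay on the whole organism (Abdomen, strain albino) for inhibition, with Mus musculus as the target, in the writhing test, with stated times of 1 h and 8 min, at a dose of 10 mg/kg by the oral route; on this read-out higher numbers stand for more inhibition at the one dose given (going by the name of the read-out) and lower numbers for less inhibition.
Compound 2 `CC1=CC[C@@H]2[C@@H](O[C@H](c3ccc([N+](=O)[O-])cc3)OC2(C)C)[C@@H]1O` gives 65%.

Among the compounds with values here, compound 1 stands highest of the two numbers, and the only measured step, a number 23 percentage points lower from compound 1 to compound 2 (beyond the scatter), swaps one group for another rather than adding one. Compound 3 `CC1=CC[C@@H]2[C@@H](O[C@H](c3ccc(Cl)c(Cl)c3)OC2(C)C)[C@@H]1O` differs from compound 1 by chloro in place of hydrogen on an aromatic carbon. Within the data shown here, no measured step covers this kind of change, so the expectation rests on the retained chloro of compound 1. A step of a number 6 percentage points lower from compound 1 to compound 3 (within the scatter) is expected in this assay, within the scatter. Compound 3 is estimated at 82%, between 62% and 96%.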

Compound 3, a percentage reported as inhibition, in the whole organism at one dose (the size of the read-out at that dose, not a potency): 14%
Compound 3: the middle estimate sits 68 percentage points above what was measured; the whole stated range lies above it.
By their numbers in this assay, from the lowest: compound 3; then compound 2; then compound 1.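

In this assay, one added chloro on an aromatic carbon, ortho to a chloro group, gives a number 74 percentage points lower from compound 1 to compound 3 (beyond the scatter) and so turns a high read-out into a low one. This hydrogen therefore cannot be replaced freely, even though the first chloro stays in place and only one heavy atom enters. Nothing available here explains the drop.

Going by these compounds, whether the loss belongs to chloro itself or to any group at this place stays open. Fluoro, methoxy or an amine there could settle that.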